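A few compounds are considered here, and "the series" means these few. Any claim that something is new, unique, unknown or untested is made for them only; others in the source may bear on it.

Compound 1 `CC(=O)OC[C@H]1O[C@@H](n2cc(CN3C(=O)/C(=C\c4ccccc4)c4ccccc43)nn2)[C@H](OC(C)=O)[C@@H](OC(C)=O)[C@@H]1OC(C)=O` gives 24100 nM in a functional assay on DU-145 cells (Homo sapiens) for cytotoxicity, read by sulforhodamine B assay, with a stated time of 48 h; on this read-out lower numbers stand for stronger inhibition and higher numbers for weaker inhibition.
Compound 2 `CC(=O)OC[C@H]1O[C@@H](n2cc(CN3C(=O)/C(=C\c4ccc(C)cc4)c4ccccc43)nn2)[C@H](OC(C)=O)[C@@H](OC(C)=O)[C@@H]1OC(C)=O` gives 9400 nM in this assay.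
Compound 3 `COc1ccc(/C=C2\C(=O)N(Cc3cn([C@@H]4O[C@H](COC(C)=O)[C@@H](OC(C)=O)[C@H](OC(C)=O)[C@H]4OC(C)=O)nn3)c3ccccc32)cc1OC` gives 24900 nM in this assay.

Compound 3 has the highest number of the three, though its gap to compound 1 is within the scatter, as a 1.0-fold higher number from compound 1 to compound 3 (0.01 log units; within the scatter) shows, while its gap to compound 2 is modest but beyond it: a 2.6-fold higher number from compound 2 to compound 3 (0.42 log units; beyond the scatter). Compound 4 `CC(=O)OC[C@H]1O[C@@H](n2cc(CN3C(=O)/C(=C\C=C\c4ccccc4)c4ccccc43)nn2)[C@H](OC(C)=O)[C@@H](OC(C)=O)[C@@H]1OC(C)=O` is the next step: 2-phenylethenyl in place of 3,4-dimethoxyphenyl on a double-bonded chain carbon bound to a double-bonded ring carbon. Both measured steps at this place were small, and none involved a 2-phenylethenyl group, so no firm direction can be drawn. Compound 4 is therefore expected to give 20000 nM in this assay, between 7000 nM and 60000 nM. The expected step from compound 3 is a 1.2-fold lower number from compound 3 to compound 4 (0.10 log units; within the scatter), most likely within the scatter.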

Compound 4, half-maximal inhibitory concentration: 19500 nM
Estimate against measurement, compound 4: 1.0-fold (0.01 log units) above, and the stated range covers the measured number.
By their numbers in this assay, from the lowest: compound 2; then compounds 4, 1 and 3 (each within the scatter of the next).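

Going by these compounds alone, on a double-bonded chain carbon bound to a double-bonded ring carbon, 2-phenylethenyl, the first group here with a double bond outside aromatic rings, leaves the number level with phenyl (a 1.2-fold lower number from compound 1 to compound 4 (0.09 log units; within the scatter)) and with 3,4-dimethoxyphenyl (a 1.3-fold lower number from compound 3 to compound 4 (0.11 log units; within the scatter)). Within the data shown here, only 4-methylphenyl stands apart (a 2.1-fold higher number from compound 2 to compound 4 (0.32 log units; beyond the scatter)), so compound 2 remains the one compound beyond the scatter of the others. No measured evidence explains this pattern. On these data alone, whether an amine, a carboxylic acid or a longer chain at this place would shift the number remains open.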